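Thiophene attachment point in a pyridine series against K562 cells

A few compounds are considered here, and "the series" means these few. Any claim that something is new, unique, unknown or untested is made for them only; others in the source may bear on it.

Compound 1 `Clc1ccc(-c2cc(-c3ccoc3)cc(-c3cccs3)n2)cc1` in a functional assay on K562 cells (Homo sapiens) for cytotoxicity, in the presence of a further agent that is not named here (a lower number here means a stronger inhibitor, a higher number a weaker inhibitor), gives 21100 nM, while compound 2 `Clc1ccc(-c2cc(-c3ccoc3)cc(-c3ccsc3)n2)cc1` gives 730 nM. The change between them is thiophen-3-yl in place of thiophen-2-yl on an aromatic carbon and the step is a 29-fold lower number from compound 1 to compound 2 (1.46 log units; beyond the scatter). Compound 3 `Cc1ccc(-c2cc(-c3ccc(Cl)o3)cc(-c3cccs3)n2)cc1` gives 21500 nM in this assay; how its core differs from that of compound 1 is not broken down here. Compound 4 `Cc1ccc(-c2cc(-c3ccc(Cl)o3)cc(-c3ccsc3)n2)cc1` is not yet measured. It differs from compound 3 by thiophen-3-yl in place of thiophen-2-yl on an aromatic carbon, the same kind of change as from compound 1 to compound 2, though here the place is meta to a 4-methylphenyl group and meta to a 5-chlorofuran-2-yl group rather than meta to a 4-chlorophenyl group and meta to a furan-3-yl group. Within the data shown here, for compound 4 a step of a 14-fold lower number from compound 3 to compound 4 (1.16 log units; beyond the scatter) is expected, resting on the single precedent a 29-fold lower number from compound 1 to compound 2 (1.46 log units; beyond the scatter) and tempered by the changed surroundings. Compound 4 is estimated at 1500 nM, between 400 nM and 8000 nM.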

Compound 4, half-maximal inhibitory concentration: 19900 nM
Compound 4: middle estimate off by 13-fold (1.12 log units), on the low side; measured number outside the range, above it.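

Thiophen-3-yl in place of thiophen-2-yl does not carry over from one core to the other in this assay: the same change on two cores in this assay, a 29-fold lower number (1.46 log units; beyond the scatter) from compound 1 to compound 2 and a 1.1-fold lower number (0.03 log units; within the scatter) from compound 3 to compound 4, 27-fold (1.43 log units) apart, beyond the scatter of two such steps. On the core of compound 3 the change gives a 1.1-fold lower number from compound 3 to compound 4 (0.03 log units; within the scatter), so the large step on the core of compound 1 does not hold for this change across the series. These two pairs show that the step depends on its surroundings, but not which difference matters, the 4-methylphenyl group against the 4-chlorophenyl group or the 5-chlorofuran-2-yl group against the furan-3-yl group.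

Among these compounds, open is whether exchanging only one of these groups would bring back the large step. Also open, from the compounds shown here alone, is how the thiophene change reads with an amine or a carboxylic acid on the core.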